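From 2-cyanocyclopropyl to 3-cyanocyclobutyl: estimating compound 3

The source may report more compounds than this note shows. Statements on the series, on what has been measured and on what is new or still open speak of the compounds shown alone.

In an ADME assay on MDCKII-LE cells (Canis lupus familiaris) for permeability (a lower number here means that the compound crosses the layer more slowly, a higher number that the compound crosses the layer faster), compound 1 `NC(=O)[C@@H](CCC(F)(F)F)N(CC12CC(c3ncon3)(C1)C2)S(=O)(=O)c1ccc(Cl)cc1` gives 19.3 10^-6 cm/s, and compound 2 `N#C[C@H]1C[C@@H]1CN([C@H](CCC(F)(F)F)C(N)=O)S(=O)(=O)c1ccc(Cl)cc1` gives 21.5 10^-6 cm/s. These two numbers lie within the usual scatter of repeated measurements, so compound 2 stands level with compound 1. Compound 3 `N#C[C@H]1C[C@@H](CN([C@H](CCC(F)(F)F)C(N)=O)S(=O)(=O)c2ccc(Cl)cc2)C1` differs from compound 2 in a single group: 3-cyanocyclobutyl in place of 2-cyanocyclopropyl on a saturated chain carbon bound to a sulfonamide nitrogen. Put simply, 3-cyanocyclobutyl sits in place of 2-cyanocyclopropyl on a saturated chain carbon bound to a sulfonamide nitrogen. Going by the values given here, only one measured step bears on this change, as it was made at the same place: a 1.1-fold higher number from compound 1 to compound 2 (0.05 log units; within the scatter). That exchange involved a much larger group and still stayed within the scatter, so no clear step up or down is expected in this assay here. The estimated step, a 1.1-fold lower number from compound 2 to compound 3 (0.03 log units; within the scatter), is expected to stay within the scatter as well. For compound 3 the estimated value is 20 10^-6 cm/s, with an expected range from 11 10^-6 cm/s to 35 10^-6 cm/s.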

Compound 3, apparent permeability: 24.1 10^-6 cm/s
The estimate for compound 3 lay 1.2-fold (0.08 log units) below the measured number; the range from low to high includes it.
By their numbers in this assay, from the lowest: compounds 1, 2 and 3 (each within the scatter of the next).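

In this assay, exchanging 2-cyanocyclopropyl for 3-cyanocyclobutyl gives a 1.1-fold higher number from compound 2 to compound 3 (0.05 log units; within the scatter), so adding one ring carbon at this place leaves the number level. Set against the much larger group at the same place, the new ring gives a 1.2-fold higher number from compound 1 to compound 3 (0.10 log units; within the scatter), so all three groups on this saturated chain carbon bound to a sulfonamide nitrogen stand level in this read-out. Nothing measured here gives a reason for these level numbers.

The compounds shown leave open what a plain cyclobutyl ring, without its nitrile, would give at this place. They also leave open whether a group with no ring at all, such as a longer chain, or one carrying an amine or a carboxylic acid, would stay level too.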